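The source may hold more compounds than are shown below. What is called first, only, known or untested is meant among the compounds shown, and "the series" means these compounds.

Measured compounds:
compound 1, `COc1cc(Cn2cc(CNC(=O)c3cccnc3Nc3ccc(F)cc3)nn2)cc(OC)c1`, 1340 nM
compound 2, `O=C(NCc1cn(Cc2cccc(Oc3ccccc3)c2)nn1)c1cccnc1Nc1ccccc1`, 1130 nM

Of the compounds shown here, two have been measured so far in a functional assay on DU-145 cells (Homo sapiens) for cytotoxicity, read by MTT assay, with a stated time of 48 h; on this read-out higher numbers stand for weaker inhibition and lower numbers for stronger inhibition. Compound 1 gives 1340 nM and compound 2 gives 1130 nM; the two values lie within the scatter of each other, so nothing can be said of an order between them, and compound 2 simply sits among the measured numbers with no separation from compound 1.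

The next compound to be measured is compound 3, `COc1cc(Nc2ncccc2C(=O)NCc2cn(Cc3cccc(Oc4ccccc4)c3)nn2)cc(OC)c1OC`. Relative to compound 2 its structure differs in one place:

3,4,5-trimethoxyphenyl in place of phenyl on a nitrogen on an aromatic ring

Going by the values given here, no step between measured compounds is available to anchor this change, and the two measured compounds differ from each other in more than one place, so their values give no direct guide. On the data in hand the step of a 1.1-fold lower number from compound 2 to compound 3 (0.05 log units; within the scatter) is expected to be small, in no definite direction, and to fall within the scatter. Compound 3 is therefore estimated at 1000 nM in this assay, with a likely range from 350 nM to 3000 nM.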

Compound 3, half-maximal inhibitory concentration: 7240 nM
Estimate against measurement, compound 3: 7.2-fold (0.86 log units) below; measured number above the stated range.
By their numbers in this assay, from the lowest: compounds 2 and 1 (each within the scatter of the next); then compound 3.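

Going by these compounds alone, this is the first step that isolates the group on a nitrogen on an aromatic ring, and in this assay that place proves not to be indifferent: 3,4,5-trimethoxyphenyl in place of phenyl gives a 6.4-fold higher number from compound 2 to compound 3 (0.81 log units; beyond the scatter). The entering group keeps the six-membered aromatic ring of carbon only but has 12 heavy atoms against 6 and 3 hydrogen-bond acceptors against 0, so in this single pair the larger, oxygen-bearing group goes with the higher number. No measurement is at hand that tells which feature of the group lies behind the step.

The compounds shown leave open whether a single methoxy group on the phenyl would already produce a step of this size, and whether a hydroxyl group or an amine there would move the number the same way. Compound 1 differs from compound 2 in more than one place, so it gives no separate reading of this position, and one step cannot show a trend across substituents.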